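Cytotoxicity limits, from compound 2 to compound 3

This account rests on a few compounds, and the source may have more. Where it says the series, first, only, none or still open, it means among the compounds named here.

- Compound 1 (`CNC(=O)[C@@H](NC(=O)[C@@](O)(CCCN(Cc1ccc(-c2ccccc2)cc1)NC(=O)[C@@H](NC(=O)OC)C(C)(C)C)Cc1ccccc1)C(C)(C)C`): > 50000 nM
- Compound 2 (`CNC(=O)[C@@H](NC(=O)[C@@](O)(CCCN(Cc1ccc(C#Cc2ccncc2)cc1)NC(=O)[C@@H](NC(=O)OC)C(C)(C)C)Cc1ccccc1)C(C)(C)C`): > 50000 nM
- Compound 3 (`CNC(=O)[C@@H](NC(=O)[C@@](O)(CCCN(Cc1ccc(-c2ccccn2)cc1)NC(=O)[C@@H](NC(=O)OC)C(C)(C)C)Cc1ccccc1)C(C)(C)C`): not yet measured

In an ADME assay on MT4 cells (Homo sapiens) for cytotoxicity, read by XTT assay, with a stated time of 5 days (a higher number here means that more compound is tolerated, a lower number that less compound is tolerated), compound 2 gives > 50000 nM, which is a limit of the assay and not a number. Compound 1 gives > 50000 nM, also a limit. The evidence so far is the limit of > 50000 nM in this assay, at which 2 of the 2 values shown sit.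

The change to compound 3 is pyridin-2-yl in place of 2-(pyridin-4-yl)ethynyl on an aromatic carbon. In words, pyridin-2-yl stands in place of 2-(pyridin-4-yl)ethynyl on an aromatic carbon, para to a large group.

Among the compounds with values here, the only measured step that bears on this is a step that the two limits leave unreadable from compound 1 to compound 2. It also exchanged the group at this place, but it offers no readable size to carry over. No step beyond the scatter is therefore expected in this assay, and no direction can be assigned. The estimate means an expected a number no higher from compound 2 to compound 3 (the limit leaves the size open). For compound 3 the expected value is 50000 nM (estimated range 25000 nM to 100000 nM).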

Compound 3, half-maximal cytotoxic concentration: > 50000 nM
Compound 3: a limit, no number; the forecaster's own chance of this, stated with the estimate: 80%; the middle value lies on the limit itself.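

In this assay compound 3 gives > 50000 nM as a limit and not a number. Within the data shown here, compound 1, compound 2 and compound 3 all stand at this one limit, and no step among them can be read. On these data alone, whether phenyl, 2-(pyridin-4-yl)ethynyl and pyridin-2-yl differ at all in cytotoxicity at this place stays open.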